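Chloro for fluoro on the aryl ring of compound 1

The compounds below may be only part of what the source reports. "The series", "measured", "known", "first", "only" and "open" are said of these compounds alone.

compound 1 `COc1cc(-c2nc(-c3ccccc3)[nH]c2-c2ccnc(NCCCNS(=O)(=O)c3cccc(F)c3)n2)ccc1F` gives 900 nM
compound 2 `COc1cc(-c2nc(-c3ccccc3)[nH]c2-c2ccnc(NCCCNS(=O)(=O)c3ccc(C)cc3)n2)ccc1F` gives 2590 nM
compound 3 `COc1cc(-c2nc(-c3ccccc3)[nH]c2-c2ccnc(NCCCNS(=O)(=O)c3cccc(F)c3)n2)ccc1Cl` has not yet been measured

In a functional assay on LOX IMVI cells (Homo sapiens) for cytotoxicity, read by MTT assay, with a stated time of 24 h (a higher number here means a weaker inhibitor, a lower number a stronger inhibitor), compound 1 holds the lower of the two numbers. Going by the values given here, the only measured step is a 2.9-fold higher number from compound 1 to compound 2 (0.46 log units; beyond the scatter), and it lies on a sulfonyl sulfur, away from the change in compound 3. Compound 3 differs from compound 1 as follows: chloro in place of fluoro on an aromatic carbon, which turns 4-fluoro-3-methoxyphenyl into 4-chloro-3-methoxyphenyl. Among the compounds with values here, no measured step covers this place, so that step offers only a rough scale. The expected change is a 1.1-fold higher number from compound 1 to compound 3 (0.05 log units; within the scatter) in this assay, slightly upward and not expected to pass the scatter. Compound 3 is estimated at 1000 nM, with an expected range from 400 nM to 2500 nM.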

Compound 3, half-maximal inhibitory concentration: 5110 nM
Beside the measured number, compound 3's estimate is 5.1-fold (0.71 log units) below it; the measured number lies above the stated range.
By their numbers in this assay, from the lowest: compound 1; then compounds 2 and 3 (each within the scatter of the next).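

In this assay, the halogen ortho to the methoxy group proves sensitive: chloro in place of fluoro brings a 5.7-fold higher number from compound 1 to compound 3 (0.75 log units; beyond the scatter). This exchange of one heavy atom for another, with no change in ring, donors, acceptors or charge, is enough to pass the scatter, so this position on the 4-fluoro-3-methoxyphenyl group is not neutral. No measurement at hand accounts for the step.

From the compounds shown here alone, whether fluoro is the best group here stays open, since a methyl group, a bromine atom or an amine at this carbon could show how far the trend runs. Also open, going by these compounds, is whether chloro costs the same alongside the 4-methylphenyl group on the sulfonyl sulfur.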